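Moving the Nitrogen Substituent from Compound 2 to Compound 3

This account rests on a few compounds, and the source may have more. Where it says the series, first, only, none or still open, it means among the compounds named here.

Values so far in a functional assay on MCF7 cells (Homo sapiens) for cytotoxicity, read by MTT assay, with a stated time of 96 h (a higher number here means a weaker inhibitor, a lower number a stronger inhibitor), are these
- compound 1 `COc1cc(C(=O)c2cn(-c3ccccc3Cl)cc2-c2ccccc2)cc(OC)c1OC` gives 1800 nM here
- compound 2 `COc1cc(C(=O)c2cn(-c3cccc([N+](=O)[O-])c3)cc2-c2ccccc2)cc(OC)c1OC` gives 550 nM here

Compound 2 holds the lower of these two numbers, which makes it the stronger inhibitor of the pair. Compound 3 `COc1ccc(-n2cc(C(=O)c3cc(OC)c(OC)c(OC)c3)c(-c3ccccc3)c2)cc1` keeps the same core but carries 4-methoxyphenyl in place of 3-nitrophenyl on an aromatic nitrogen. For the measured compounds named here, the one measured step that bears on this is a 3.3-fold lower number from compound 1 to compound 2 (0.51 log units; beyond the scatter) and it was modest, made on that same aromatic nitrogen. Going by the values given here, one step is thin evidence, but since compound 2 sits at the low end, a move toward a higher number in this assay is expected, no larger than that step. The expected change is a 1.8-fold higher number from compound 2 to compound 3 (0.26 log units; within the scatter) (an estimate). Compound 3 is estimated at 1000 nM (range 300 nM to 3000 nM).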

Compound 3, half-maximal inhibitory concentration: 120 nM
Compound 3: middle estimate off by 8.3-fold (0.92 log units), on the high side; the measured number lies below the stated range.
By their numbers in this assay, from the lowest: compound 3; then compound 2; then compound 1.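

The low end of this position had not yet been reached: in this assay, 4-methoxyphenyl in place of 3-nitrophenyl on the aromatic nitrogen gives a 4.6-fold lower number from compound 2 to compound 3 (0.66 log units; beyond the scatter), and the number falls further than the first step suggested. Setting 4-methoxyphenyl against 2-chlorophenyl gives a 15-fold lower number from compound 1 to compound 3 (1.18 log units; beyond the scatter), so changing this one group, with the shared core held fixed, can move the number a long way. Nothing available explains why 4-methoxyphenyl gives the lowest number of the three.

These three groups differ both in what the ring carries and in where it carries it, so the effect of the methoxy group cannot be separated from that of its ring position. The compounds shown leave open how 3-methoxyphenyl, 2-methoxyphenyl or 4-aminophenyl would compare on this nitrogen.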